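Sulfonamide hydrazide series: note toward compound 3

The source may hold more compounds than are shown below. What is called first, only, known or untested is meant among the compounds shown, and "the series" means these compounds.

Measured so far:
compound 1 `O=C(NNc1ccccc1Cl)c1cccc(NS(=O)(=O)c2cnc(O)nc2O)c1` — 2270 nM
compound 2 `O=C(NNC(=O)c1ccccc1Cl)c1ccc(NS(=O)(=O)c2cnc(O)nc2O)cc1` — 3240 nM

Both compounds share the sulfonamide-bearing core and were read in a functional assay on SGC-7901 cells (Homo sapiens) for antiproliferative activity, read by MTT assay, with a stated time of 24 h; on this read-out lower numbers stand for stronger inhibition and higher numbers for weaker inhibition. Compound 1 gives 2270 nM and compound 2 gives 3240 nM; the gap between them lies within the scatter, so no order between the two is claimed, and compound 1 stands only as the lower of the two numbers as read.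

Compound 3 `O=C(NNC(=O)c1ccccc1F)c1cccc(NS(=O)(=O)c2cnc(O)nc2O)c1` is not yet measured. Relative to compound 1 the change is (2-fluorophenyl)carbonyl in place of 2-chlorophenyl on an amine nitrogen. Within the data shown here, compound 2 already carries a (2-chlorophenyl)carbonyl on the corresponding amine nitrogen, and its value in this assay sits close to that of compound 1, which is the only guide available for a carbonyl-bearing variant of this kind. Among the measured compounds shown here, no step between measured compounds is available that isolates the change itself.

Expectation: compound 3 should give a number of the same order as compound 1, with the step from compound 1 to compound 3 estimated at a 1.2-fold higher number from compound 1 to compound 3 (0.09 log units; within the scatter), not beyond the scatter in either direction. Compound 3 is estimated at 2800 nM, within 1200 nM to 7000 nM.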

Compound 3, half-maximal inhibitory concentration: > 20000 nM
Compound 3: no number, only a limit; the forecaster's own chance of this, stated with the estimate: 5%; middle value at least 7.1-fold (0.85 log units) away from the limit.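

In this assay compound 3 gives > 20000 nM, which is a limit of the assay and not a number. Placing (2-fluorophenyl)carbonyl in place of 2-chlorophenyl on this amine nitrogen gives an at least 8.8-fold higher number from compound 1 to compound 3 (0.94 log units; beyond the scatter); this is the first step in the series confined to one place and the first read as beyond the scatter, so the group carried on this nitrogen can decide whether activity is seen at all within the range of the assay. The true size of the step stays unresolved, and only its lower bound can be stated: the limit of > 20000 nM in this assay, at which 1 of the 3 values shown sits.

The change combines two differences, a carbonyl entering and fluorine standing where chlorine stood, and the compounds shown do not separate them: a 2-fluorophenyl on this amine nitrogen, or a (2-chlorophenyl)carbonyl there on the core of compound 3, would be the compounds to read. Also open, going by these compounds, is whether any other group at this place, such as a simple methyl, a pyridyl ring or a phenyl bearing a carboxylic acid, keeps the activity of compound 1.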